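This account rests on a few compounds, and the source may have more. Where it says the series, first, only, none or still open, it means among the compounds named here.

Compound 1 `CCCSc1nc(N/N=C/c2ccc(Cl)cc2)c2nnn(Cc3ccccc3)c2n1` is examined in a functional assay on ECa-109 cells (Homo sapiens) for antiproliferative activity, read by MTT assay, with a stated time of 72 h; a higher number here means a weaker inhibitor, a lower number a stronger inhibitor. In this assay compound 1 gives > 64000 nM, and this is a limit of the assay rather than a number. The weak end of the shown set is marked by that limit (the limit of > 64000 nM in this assay, at which 1 of the 3 values shown sits). Compound 2 `CCCSc1nc(N/N=C/c2ccc(N(C)C)cc2)c2nnn(Cc3ccccc3)c2n1` gives 20000 nM and compound 3 `CCCSc1nc(N/N=C/c2ccc([N+](=O)[O-])cc2)c2nnn(Cc3ccccc3)c2n1` gives 6640 nM, so compound 1 stands as the weakest of the three measured compounds. The step under review leads to compound 4 `CCCSc1nc(N/N=C(\C)c2ccc(Br)cc2)c2nnn(Cc3ccccc3)c2n1`: a group of 10 heavy atoms (8 carbon, 1 nitrogen, 1 bromine; one six-membered aromatic ring of carbon only) in place of a group of 9 heavy atoms (7 carbon, 1 nitrogen, 1 chlorine; one six-membered aromatic ring of carbon only), on a nitrogen on an aromatic ring. The steps measured so far alter only the group on the six-membered aromatic ring of carbon only: an at least 3.2-fold lower number from compound 1 to compound 2 (0.50 log units; beyond the scatter), an at least 9.6-fold lower number from compound 1 to compound 3 (0.98 log units; beyond the scatter) and a 3.0-fold lower number from compound 2 to compound 3 (0.48 log units; beyond the scatter). None of them exchanges the halogen or enlarges the group on the nitrogen, so they bear on the step to compound 4 only loosely, showing that changes at that ring move the number by a modest or larger amount. Because compound 1 sits at the limit (the limit of > 64000 nM in this assay, at which 1 of the 3 values shown sits), compound 4 is expected to stay near it, with an at least 1.0-fold lower number from compound 1 to compound 4 (0.02 log units; that floor lies within the scatter) as the expected step. Compound 4 is therefore estimated at 60000 nM, within 20000 nM to 200000 nM.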

Compound 4, half-maximal inhibitory concentration: 4670 nM
The estimate for compound 4 lay 13-fold (1.11 log units) above the measured number; measured number outside the range, below it.
By their numbers in this assay, from the lowest: compounds 4 and 3 (each within the scatter of the next); then compound 2. At a limit, above all of these: compound 1.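

In this assay, the exchange of the group on a nitrogen on an aromatic ring gives an at least 13-fold lower number from compound 1 to compound 4 (1.13 log units; beyond the scatter). Among these compounds, compound 1 gives > 64000 nM, which is a limit and not a number, so this step is known only as a floor: the limit of > 64000 nM in this assay, at which 1 of the 4 values shown sits. The earlier steps altered only the group on the six-membered aromatic ring of carbon only, whereas this one shows that a group with one more carbon and with bromine in place of chlorine, set on that nitrogen, can move the number by a large amount.

The compounds shown leave open how much of the step belongs to the bromine and how much to the added carbon. They also leave open how an amine or a carboxylic acid in place of the bromine would read in this assay.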